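A Sulfur Ring in Place of a Fluorinated Ring

This account rests on a few compounds, and the source may have more. Where it says the series, first, only, none or still open, it means among the compounds named here.

Measured in a functional assay on HEK293 cells for antagonist activity at transient receptor potential M8 protein (Canis lupus familiaris), read by FLIPR and calcium flux; a lower number here means a stronger inhibitor, a higher number a weaker inhibitor:
Compound 1, `Clc1ccccc1-c1ccc2[nH]c(/C=C/C3CCCCC3)nc2c1`: 8.9 nM
Compound 2, `FC(F)(F)c1cccc(C(F)(F)F)c1-c1ccc2[nH]c(/C=C/C3CCCCC3)nc2c1`: 12.3 nM
Compound 3, `CC1(/C=C/c2nc3cc(-c4ccccc4C(F)(F)F)ccc3[nH]2)CCC(F)(F)CC1`: 8.9 nM

Compound 3 stands level with compound 1 at the digits shown, the two together giving the lowest numbers of the three, and compound 2 lies within the scatter of both. No two of these compounds differ in only one place, so no measured single step exists to lean on. Compound 4, `FC(F)(F)c1ccccc1-c1ccc2[nH]c(/C=C/C3CCSCC3)nc2c1`, is compound 3 with thian-4-yl in place of 4,4-difluoro-1-methylcyclohexyl on a double-bonded chain carbon bound to a double-bonded chain carbon. Compound 1 carries a plain carbon ring of the same size on that chain carbon, and in this assay compound 1 gives 8.9 nM, level with compound 3. Compound 4 is therefore expected to give about 12 nM, within a range from 4 nM to 40 nM. The expected step of a 1.3-fold higher number from compound 3 to compound 4 (0.13 log units; within the scatter) is none beyond the scatter.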

Compound 4, half-maximal inhibitory concentration: 31 nM
The estimate for compound 4 lay 2.6-fold (0.41 log units) below the measured number; low and high end bracket the measured number.
By their numbers in this assay, from the lowest: compounds 1, 3 and 2 (each within the scatter of the next); then compound 4.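

In this assay, among the compounds shown here, this is the first change that can be read on its own: thian-4-yl in place of 4,4-difluoro-1-methylcyclohexyl gives a 3.5-fold higher number from compound 3 to compound 4 (0.54 log units; beyond the scatter) on a double-bonded chain carbon bound to a double-bonded chain carbon. The ring at this position therefore matters, and this sulfur ring gives the weaker inhibitor of the pair. No measurement here bears on why the number rises. Still open, on these data alone, is whether the sulfur, the two fluorines or the methyl group accounts for the step. Also open, as far as these compounds go, is how a piperidin-4-yl ring, which carries an amine, would behave at this position.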